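Head-Group Change from Compound 1 to Compound 4

The source may report more compounds than this note shows. Statements on the series, on what has been measured and on what is new or still open speak of the compounds shown alone.

Compound 1 `Cc1nc(-c2ccc(C(F)(F)F)cc2)sc1CNc1ccc(CCC(=O)O)cc1`: 67.6 nM
Compound 2 `O=C(O)CSc1ccc(NCc2cccc(Oc3ccccc3)c2)cc1`: 324 nM
Compound 3 `CNC(=O)CCc1ccc(NCc2cccc(Oc3ccccc3)c2)cc1`: 49 nM

In a functional assay on CHO cells for agonist activity at Free fatty acid receptor 1 (Homo sapiens) (on this read-out lower numbers stand for an effect already at smaller amounts and higher numbers for an effect only at larger amounts of compound), compound 1 gives 67.6 nM, the second highest of the three numbers; the values of compound 1 and compound 3 lie within the usual scatter of each other, whereas compound 2 gives a clearly higher number. Compound 4 `Cc1nc(-c2ccc(C(F)(F)F)cc2)sc1CNc1ccc([C@H]2C[C@@H]2C(=O)NO)cc1` differs from compound 1 in one place: 2-(hydroxycarbamoyl)cyclopropyl in place of 2-carboxyethyl on an aromatic carbon. Within the data shown here, the only measured step that bears on this is a 6.6-fold lower number from compound 2 to compound 3 (0.82 log units; beyond the scatter), where (carboxymethyl)sulfanyl gave way to 2-(methylcarbamoyl)ethyl on another core and the number fell. That step hints that the 2-carboxyethyl group is not indispensable, yet it is a different change on a different core, so guidance is weak. One therefore expects compound 4 to land near compound 1, with a step of a 1.5-fold higher number from compound 1 to compound 4 (0.17 log units; within the scatter) and an estimated 100 nM, ranging from 30 nM to 400 nM.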

Compound 4, half-maximal effective concentration: 6.92 nM
Beside the measured number, compound 4's estimate is 14-fold (1.16 log units) above it; the whole stated range lies above it.
By their numbers in this assay, from the lowest: compound 4; then compounds 3 and 1 (each within the scatter of the next); then compound 2.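

In this assay, 2-(hydroxycarbamoyl)cyclopropyl in place of 2-carboxyethyl gives a 9.8-fold lower number from compound 1 to compound 4 (0.99 log units; beyond the scatter), so this position, para to a large group, does not need the carboxylic acid on the core of compound 1. The earlier step, a 6.6-fold lower number from compound 2 to compound 3 (0.82 log units; beyond the scatter), was read on another core and could not show this. Nothing measured here explains the fall in the number. As far as these compounds go, both the hydroxycarbamoyl group and the cyclopropyl ring enter together, so their shares stay open: a 2-carboxycyclopropyl group or a 2-(hydroxycarbamoyl)ethyl chain would separate them. From the compounds shown here alone, how the opposite stereoisomer behaves also stays open.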